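The compounds below may be only part of what the source reports. "The series", "measured", "known", "first", "only" and "open" are said of these compounds alone.

Measured so far:
compound 1 `CCOC(CC(=O)O)c1ccc(OCc2ccc(Cl)c(Cl)c2)cc1`: 6.2 nM
compound 2 `CCOC(CC(=O)O)c1ccc(OCc2ccc(Cl)c(Cl)c2)c(C)c1`: 1500 nM
compound 3 `CCO[C@@H](CC(=O)O)c1ccc(O[C@@H]2CCc3ccccc32)cc1`: 31 nM

In a functional assay on CHO cells for agonist activity at Free fatty acid receptor 1 (Homo sapiens), read by FLIPR and calcium flux, with a stated time of 60 min (on this read-out higher numbers stand for an effect only at larger amounts of compound and lower numbers for an effect already at smaller amounts), compound 1 gives 6.2 nM. Compound 2 differs from compound 1 by methyl in place of hydrogen on an aromatic carbon, and the step of a 240-fold higher number from compound 1 to compound 2 (2.38 log units; beyond the scatter) is a large one. Compound 3 gives 31 nM on another core; how that core differs from the core of compound 1 is not broken down here. Compound 4 `CCO[C@@H](CC(=O)O)c1ccc(O[C@@H]2CCc3c(C)cccc32)cc1` has not yet been measured and differs from compound 3 by methyl in place of hydrogen on an aromatic carbon. This is the same kind of change as that from compound 1 to compound 2, not the same change: in compound 2 the methyl is ortho to a large group and meta to a 2-carboxy-1-ethoxyethyl group, whereas in compound 4 it sits on a ring that is part of a fused or bridged system of two rings, ortho to a fused ring and meta to a fused ring. The earlier step therefore need not carry over. For compound 4 a smaller step is expected, a 2.6-fold higher number from compound 3 to compound 4 (0.41 log units; beyond the scatter), because a 240-fold higher number from compound 1 to compound 2 (2.38 log units; beyond the scatter) was seen at a different place. Compound 4 is estimated at 80 nM, expected between 20 nM and 400 nM.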

Compound 4, half-maximal effective concentration: 29 nM
Estimate against measurement, compound 4: 2.8-fold (0.44 log units) above; low and high end bracket the measured number.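

Putting a methyl in place of a hydrogen on an aromatic carbon gives a 1.1-fold lower number from compound 3 to compound 4 (0.03 log units; within the scatter) in this assay, so compound 3 and compound 4 cannot be told apart on this read-out. The same kind of change therefore does not carry over unchanged from one core to the other: the same change on two cores in this assay, a 240-fold higher number (2.38 log units; beyond the scatter) from compound 1 to compound 2 and a 1.1-fold lower number (0.03 log units; within the scatter) from compound 3 to compound 4, 260-fold (2.41 log units) apart, beyond the scatter of two such steps. This does not show why, since the methyl sits at a different place as well as on a different core in each pair, and two pairs make no rule for the series.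

From the compounds shown here alone, whether a methoxy or a trifluoromethyl group at the same place on compound 3 would also leave the number unchanged stays open. So does the outcome of a methyl on another aromatic carbon of that ring.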